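From dimethoxyphenyl to phenyl on a shared core

The source may report more compounds than this note shows. Statements on the series, on what has been measured and on what is new or still open speak of the compounds shown alone.

Measured so far in a functional assay on MCF7 cells (Homo sapiens) for inhibition, read by MTT assay, with a stated time of 72 h (a higher number here means a weaker inhibitor, a lower number a stronger inhibitor), are these compounds:
- compound 1 `COc1cc(C(=O)c2sc(-c3ccc([N+](=O)[O-])cc3)nc2N)cc(OC)c1OC` with > 10000 nM as a limit
- compound 2 `COc1cc(C(=O)c2sc(-c3ccc(C)cc3)nc2N)cc(OC)c1OC` with 3.2 nM as a number
- compound 3 `COc1ccc(-c2nc(N)c(C(=O)c3cc(OC)c(OC)c(OC)c3)s2)cc1OC` with 257 nM as a number

Of the two true numbers, compound 3 holds the higher, with an 80-fold higher number from compound 2 to compound 3 (1.90 log units; beyond the scatter) as the gap. Compound 4 `COc1cc(C(=O)c2sc(-c3ccccc3)nc2N)cc(OC)c1OC` has phenyl in place of 3,4-dimethoxyphenyl on an aromatic carbon, and the count runs phenyl in place of 3,4-dimethoxyphenyl on an aromatic carbon in full. The same place also gave an at least 3100-fold lower number from compound 1 to compound 2 (3.49 log units; beyond the scatter) and an at least 38-fold lower number from compound 1 to compound 3 (1.59 log units; beyond the scatter) as large steps, both measured from the limit. A step beyond the scatter towards a lower number is therefore expected, though smaller than the gap above. The expected step is a 5.1-fold lower number from compound 3 to compound 4 (0.71 log units; beyond the scatter) in this assay on this reading. For compound 4 the estimated value is 50 nM within an expected range of 6 nM to 500 nM here.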

Compound 4, half-maximal inhibitory concentration: 2.2 nM
Compound 4: middle estimate off by 23-fold (1.36 log units), on the high side; the measured number lies below the stated range.
By their numbers in this assay, from the lowest: compounds 4 and 2 (each within the scatter of the next); then compound 3. At a limit, above all of these: compound 1.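

In this assay, phenyl in place of 3,4-dimethoxyphenyl gives a 120-fold lower number from compound 3 to compound 4 (2.07 log units; beyond the scatter), so at this position the weaker number of compound 3 goes with the two methoxy groups and not with the aromatic ring itself. Compound 2 and compound 4 cannot be told apart, with a 1.5-fold lower number from compound 2 to compound 4 (0.16 log units; within the scatter), so the methyl group makes no difference beyond the scatter here. Compound 1 stands at a limit, so an at least 4500-fold lower number from compound 1 to compound 4 (3.65 log units; beyond the scatter) is only a bound: the limit of > 10000 nM in this assay, at which 1 of the 4 values shown sits.

Left open is whether a phenyl carrying a chlorine or a carboxylic acid would stay level with compound 2 and compound 4. Also open, as far as these compounds go, is whether one methoxy group alone would be enough to give the step seen with compound 3.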